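From Phenyl to Benzofuranyl in a Nucleoside Series

This account rests on a few compounds, and the source may have more. Where it says the series, first, only, none or still open, it means among the compounds named here.

Compound 2 `Nc1nc(N)c2c(-c3ccccc3)cn([C@@H]3O[C@H](CO)[C@@H](O)[C@H]3O)c2n1` shares its core with compound 1 `COc1nc(N)nc2c1c(-c1ccccc1)cn2[C@@H]1O[C@H](CO)[C@@H](O)[C@H]1O` and compound 3 `Nc1nc2c(c(-c3cccs3)cn2[C@@H]2O[C@H](CO)[C@@H](O)[C@H]2O)c(=O)[nH]1`. In an ADME assay on MRC5 cells (Homo sapiens), read by MTT assay, with a stated time of 72 h (on this read-out lower numbers stand for stronger inhibition and higher numbers for weaker inhibition), compound 2 gives > 100000 nM, which is a limit of the assay rather than a number. Compound 1 gives > 100000 nM in this assay, likewise a limit. Compound 3 gives > 100000 nM in this assay, again a limit. Among the compounds with values here, the one change between measured compounds, amino in place of methoxy on an aromatic carbon, is a step that the two limits leave unreadable from compound 1 to compound 2; the three values sit together at the limit of > 100000 nM in this assay, at which 3 of the 3 values shown sit, so compound 2 stands where every measured compound stands, at the limit.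

Compound 4 `Nc1nc(N)c2c(-c3cc4ccccc4o3)cn([C@@H]3O[C@H](CO)[C@@H](O)[C@H]3O)c2n1` differs from compound 2 by 1-benzofuran-2-yl in place of phenyl on an aromatic carbon. Within the data shown here, no measured step bears on this change, and the single step that exists is unreadable, so no size of step in this assay can be drawn from the data. Compound 4 is therefore expected to remain at the limit, with an estimated 100000 nM and a range from 30000 nM to 300000 nM. The expected step from compound 2 is a number no higher from compound 2 to compound 4 (the limit leaves the size open).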

Compound 4, half-maximal inhibitory concentration: 78500 nM
For compound 4 the middle estimate is 1.3-fold (0.11 log units) above the measured one, within the range that was stated.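

At this place on the shared core, on an aromatic carbon two ring bonds from the ring nitrogen, the group can bring a reading in this assay that is a number and not a limit. With 1-benzofuran-2-yl in place of phenyl the result is an at least 1.2-fold lower number from compound 2 to compound 4 (0.10 log units; that floor lies within the scatter), so the data show only a small floor, and the full size of the change remains unread. Compound 4 is thus the one compound shown with a number: the limit of > 100000 nM in this assay, at which 3 of the 4 values shown sit.

On these data alone, whether a furan-2-yl group, an amine or a longer chain at this place would also give a number remains open. So does whether 1-benzofuran-2-yl would give a number with the methoxy group of compound 1 on the core.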